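The compounds below may be only part of what the source reports. "The series", "measured", "known", "first", "only" and "open" are said of these compounds alone.

In a functional assay on A2780 cells (Homo sapiens) for antiproliferative activity, read by fluorescence, with a stated time of 72 h (on this read-out lower numbers stand for stronger inhibition and higher numbers for weaker inhibition), compound 1 `CN1CCC(C(=O)N2Cc3c(NC(=O)c4ccc(F)c(F)c4)n[nH]c3C2(C)C)CC1` gives 100 nM, and compound 2 `CN1CCC(C(=O)Nc2n[nH]c3c2CN(C(=O)C(C)(C)C)C3(C)C)CC1` gives 350 nM. Compound 1 has the lower of the two numbers, and the gap between them lies beyond the scatter. Compound 3 `CN1CCC(C(=O)N2Cc3c(NC(=O)c4ccccc4)n[nH]c3C2(C)C)CC1` keeps the core of compound 1 and alters one group: phenyl in place of 3,4-difluorophenyl on a carbonyl carbon. Among the measured compounds shown here, no measured pair shows this change on its own, so any forecast is tentative. In this assay, a modest rise in the number is expected, with the estimated step being a 1.6-fold higher number from compound 1 to compound 3 (0.20 log units; within the scatter). Compound 3 is expected at 160 nM, with an estimated range from 60 nM to 420 nM.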

Compound 3, half-maximal inhibitory concentration: 160 nM
Compound 3: middle estimate and measured number agree at the digits printed; the measured number falls inside the stated range.
By their numbers in this assay, from the lowest: compounds 1 and 3 (each within the scatter of the next); then compound 2.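

In this assay, among the compounds shown here, the swap of 3,4-difluorophenyl for phenyl on a carbonyl carbon reads a 1.6-fold higher number from compound 1 to compound 3 (0.20 log units; within the scatter) and is the first view of this position with all else held the same. The two groups cannot be told apart here, so the fluorine atoms are not needed for a number in this range. No measurement at hand offers an explanation for this result. As far as these compounds go, what a pyridine ring, a cyclohexyl group or a methoxy group on the phenyl ring would do at this position stays open. So does whether a single fluorine would read like either of these groups.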